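Fluoro in Place of Bromo: Compound 3 to Compound 4

The source may report more compounds than this note shows. Statements on the series, on what has been measured and on what is new or still open speak of the compounds shown alone.

Compound 1 `COc1ccc2[nH]c3c(c2c1)CCNC31CCN(Cc2cc(F)cc(Cl)c2)CC1`, compound 2 `COc1ccc2[nH]c3c(c2c1)CCNC31CCN(Cc2c(F)ccc(Cl)c2F)CC1` and compound 3 `COc1ccc2[nH]c3c(c2c1)CCNC31CCN(Cc2ccc(Br)cc2F)CC1` share one core and differ only in the group on the saturated chain carbon bound to the amine nitrogen in a ring. In an assay on FRT cells for positive allosteric modulation of Cystic fibrosis transmembrane conductance regulator variant N1303K (Homo sapiens), in the presence of a further agent that is not named here (a lower number here means that less compound is needed, a higher number that more compound is needed for the effect), compound 1 gives 2500 nM, compound 2 gives 1500 nM, and compound 3 gives 1600 nM. The steps of a 1.7-fold lower number from compound 1 to compound 2 (0.22 log units; within the scatter), a 1.6-fold lower number from compound 1 to compound 3 (0.19 log units; within the scatter) and a 1.1-fold higher number from compound 2 to compound 3 (0.03 log units; within the scatter) all stay within the scatter, so compound 3 sits among the others without a rank of its own. Compound 4 `COc1ccc2[nH]c3c(c2c1)CCNC31CCN(Cc2ccc(F)cc2F)CC1` carries fluoro in place of bromo on an aromatic carbon. For the measured compounds named here, no measured step exchanges one halogen for another at a single position. Because a 1.6-fold lower number from compound 1 to compound 3 (0.19 log units; within the scatter) and a 1.1-fold higher number from compound 2 to compound 3 (0.03 log units; within the scatter) remain within the scatter, compound 4 is expected to show no change at the digits printed from compound 3 to compound 4 (within the scatter). Compound 4 is estimated to give 1600 nM, within 800 nM to 3200 nM.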

Compound 4, half-maximal effective concentration: 2000 nM
For compound 4 the middle estimate is 1.3-fold (0.10 log units) below the measured one; low and high end bracket the measured number.
By their numbers in this assay, from the lowest: compounds 2, 3, 4 and 1 (each within the scatter of the next).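

Exchanging one halogen for another at a single position can now be read directly: in this assay, fluoro in place of bromo para to a large group gives a 1.3-fold higher number from compound 3 to compound 4 (0.10 log units; within the scatter) and stays within the scatter. The 2,4-difluorophenyl group also stays within the scatter of the other two aryl groups, with a 1.3-fold higher number from compound 2 to compound 4 (0.12 log units; within the scatter) and a 1.3-fold lower number from compound 1 to compound 4 (0.10 log units; within the scatter). No available evidence explains these results.

Going by these compounds, whether this position accepts a group other than a halogen remains open, for example an amine, a nitrile or a carboxylic acid. On these data alone, whether any such group would give a step beyond the scatter also remains open.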